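The source may hold more compounds than are shown below. What is called first, only, known or untested is meant among the compounds shown, and "the series" means these compounds.

Measured in a functional assay on MCF7 cells (Homo sapiens) for inhibition, read by MTT assay, with stated times of 18 h and 4 h; on this read-out lower numbers stand for stronger inhibition and higher numbers for weaker inhibition:
- Compound 1 `CCCCCCCCCCOP(=O)(O)OCCSC(=S)N1CCCC1`: 70000 nM
- Compound 2 `CCCCCCCCCCCCCCCCOP(=O)(O)OCCSC(=S)N1CCN(C)CC1`: > 100000 nM
- Compound 3 `CCCCCCOP(=O)(O)OCCSC(=S)N1CCCC1`: 100000 nM

The value of > 100000 nM for compound 2 is a limit of the assay and not a number. Among the two numerical results, compound 3 gives 100000 nM, and it cannot be separated from compound 1, as the step of a 1.4-fold higher number from compound 1 to compound 3 (0.15 log units; within the scatter) shows.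

The next compound is compound 4 `CCCCCCCCCCCCCCCCOP(=O)(O)OCCSC(=S)N1CCCC1`, which has not yet been measured. It departs from compound 3 through (decyl in place of hydrogen on a saturated chain carbon, six bonds along the chain from an oxygen on an unsaturated carbon). For the measured compounds named here, only one measured step bears on this change, at the same saturated chain carbon: a 1.4-fold higher number from compound 1 to compound 3 (0.15 log units; within the scatter). That step exchanges butyl for hydrogen and stays inside the scatter, so it gives little guidance for the larger decyl addition. A modest fall in this assay is therefore expected, at most near the edge of the scatter, though no change at all would not be surprising. The expected move is a 2.0-fold lower number from compound 3 to compound 4 (0.30 log units; within the scatter). For compound 4 the estimated value is 50000 nM, with an expected range from 15000 nM to 120000 nM.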

Compound 4, half-maximal inhibitory concentration: 72000 nM
For compound 4 the middle estimate is 1.4-fold (0.16 log units) below the measured one, and the stated range covers the measured number.
By their numbers in this assay, from the lowest: compounds 1, 4 and 3 (each within the scatter of the next).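

In this assay, the chain on this saturated chain carbon does not separate the compounds: decyl in place of hydrogen gives a 1.4-fold lower number from compound 3 to compound 4 (0.14 log units; within the scatter), and hexyl in place of hydrogen gives a 1.0-fold higher number from compound 1 to compound 4 (0.01 log units; within the scatter). Pyrrolidin-1-yl in place of 4-methylpiperazin-1-yl on a thiocarbonyl carbon gives the first step at that place, an at least 1.3-fold lower number from compound 2 to compound 4 (0.14 log units; that floor lies within the scatter), and it offers only a floor. The value of compound 2 is a limit and not a number: the limit of > 100000 nM in this assay, at which 1 of the 4 values shown sits.

As far as these compounds go, whether a chain shorter than hexyl, or a carboxylic acid or an amine at the chain end, would give a value apart from these remains open. So does the outcome of a morpholine or an open-chain dialkylamine on the thiocarbonyl carbon.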